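Ortho substituent swap on the pendant phenyl of the core

A few compounds are considered here, and "the series" means these few. Any claim that something is new, unique, unknown or untested is made for them only; others in the source may bear on it.

Compound 2 `COc1ccccc1-c1cn2ccnc2c(-c2ccc3ncn(C4CCCCC4)c3c2)n1` holds the higher of the two numbers in a functional assay on PC-3 cells (Homo sapiens) for inhibition, read by sulforhodamine B assay, with a stated time of 48 h, tested at 10 uM (on this read-out lower numbers stand for less inhibition and higher numbers for more inhibition at the one concentration tested (going by the name of the read-out)), where compound 2 gives 43.1%; compound 1 `Clc1ccc(-c2cn3ccnc3c(-c3ccc4ncn(C5CCCCC5)c4c3)n2)cc1` in this assay gives 24.6%. The step of a number 18.5 percentage points higher from compound 1 to compound 2 (beyond the scatter) changes both the group and its place, so it bears only loosely on compound 3 `Fc1ccccc1-c1cn2ccnc2c(-c2ccc3ncn(C4CCCCC4)c3c2)n1`, which differs from compound 2 by fluoro in place of methoxy on an aromatic carbon. Going by the values given here, no measured step swaps groups at the same place, so the direction is uncertain; a small step downward is expected, a number 7.1 percentage points lower from compound 2 to compound 3 (within the scatter). Compound 3 is estimated at 36%, within 18% to 54%.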

Compound 3, a percentage reported as inhibition, at one concentration (the size of the read-out at that concentration, not a potency): 32.6%
For compound 3 the middle estimate is 3.4 percentage points above the measured one, and the stated range covers the measured number.
By their numbers in this assay, from the lowest: compounds 1 and 3 (each within the scatter of the next); then compound 2.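

In this assay, the swap at the place ortho to a large group shows that the group held there counts: fluoro in place of methoxy gives a number 10.5 percentage points lower from compound 2 to compound 3 (beyond the scatter) and does not keep the full number of compound 2. With 2-fluorophenyl in place of 4-chlorophenyl, the change is a number 8 percentage points higher from compound 1 to compound 3 (within the scatter), so the rise seen with 2-methoxyphenyl is not shared beyond the scatter. No measured evidence accounts for either step.

Open, from the compounds shown here alone, is how an amine or a carboxylic acid would read at this same place, and whether chloro there would sit with fluoro or with methoxy.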